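Swapping Ethyl for Cyclopropyl at the Assay Limit

The source may hold more compounds than are shown below. What is called first, only, known or untested is meant among the compounds shown, and "the series" means these compounds.

compound 1 `COc1ccc(-c2nc3cnccc3n2-c2cc(OC)c(OC)c(OC)c2)cc1O`: > 20000 nM (a limit)
compound 2 `COc1ccc(-n2c(=O)[nH]c3cnc(-c4cc(OC)c(OC)c(OC)c4)cc32)cc1O`: > 20000 nM (a limit)
compound 3 `CCn1c(=O)n(-c2cc(OC)c(OC)c(OC)c2)c2cc(-c3ccc(OC)c(O)c3)ncc21`: > 20000 nM (a limit)

These compounds were tested in a functional assay on A2780 cells (Homo sapiens) for antiproliferative activity, read by MTT assay, with a stated time of 48 h; on this read-out higher numbers stand for weaker inhibition and lower numbers for stronger inhibition. None of the three has yielded an actual number, only a limit: the limit of > 20000 nM in this assay, at which 3 of the 3 values shown sit. Compound 3 therefore has no exact position. Its result of > 20000 nM is a limit.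

The next compound, compound 4 `COc1ccc(-c2cc3c(cn2)n(C2CC2)c(=O)n3-c2cc(OC)c(OC)c(OC)c2)cc1O`, has cyclopropyl in place of ethyl on an aromatic nitrogen. Among the measured compounds shown here, no measured pair shows what a single change does in this set, so the expectation rests on the limit shared by the three compounds. A change of this small size is expected to make no difference beyond the usual scatter, and compound 4 will most likely also return only a limit. The expected step is a number no higher from compound 3 to compound 4 (the limit leaves the size open). For compound 4, the estimated value is 20000 nM, with an expected range from 8000 nM to 40000 nM.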

Compound 4, half-maximal inhibitory concentration: > 20000 nM
Compound 4: no number, only a limit (the forecaster's own chance of this, stated with the estimate: 80%); the middle value sits exactly at the limit.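

No step can be read from compound 3 to compound 4, because both results are limits and not numbers: the limit of > 20000 nM in this assay, at which 4 of the 4 values shown sit.

The compounds shown leave open what cyclopropyl in place of ethyl actually does, and whether any compound of this kind would give a measurable number.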